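The source may hold more compounds than are shown below. What is called first, only, known or untested is meant among the compounds shown, and "the series" means these compounds.

Measured compounds:
Compound 1, `O=C(CCCCCCCOc1cccc(-c2nc3ccc(-c4nc5ccccc5[nH]4)cc3[nH]2)c1)NO`, gives only a limit in an assay on isolated protein for inhibition of histone deacetylase 8 (Homo sapiens), read by fluorescence, with a stated time of 30 min (on this read-out lower numbers stand for stronger inhibition and higher numbers for weaker inhibition), > 20000 nM.
Compound 2, `O=C(CCCCCCOc1cccc(-c2nc3ccccc3[nH]2)c1)NO`, gives 5980 nM in this assay.

Going by the values given here, compound 2 holds the only numerical value in this assay; the other entry is a limit, not a number, as noted in the limit of > 20000 nM in this assay, at which 1 of the 2 values shown sits. Among the compounds with values here, compound 1 and compound 2 differ in more than one place, so no single step between them can be read.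

Compound 3, `O=C(CCCCCCCOc1cccc(-c2nc3ccccc3[nH]2)c1)NO`, has not yet been measured. It differs from compound 2 by (hydroxycarbamoyl)methyl in place of hydroxycarbamoyl on a saturated chain carbon, six bonds along the chain from an oxygen on an aromatic ring. Within the data shown here, no measured step of this kind is available, so the expectation rests on compound 2 alone. The added chain carbon is expected to move the value little, with a step of a 1.2-fold lower number from compound 2 to compound 3 (0.08 log units; within the scatter) from compound 2 to compound 3 that should fall within the usual scatter. Compound 3 is therefore estimated at 5000 nM, with a range from 1500 nM to 16000 nM.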

Compound 3, half-maximal inhibitory concentration: 12.9 nM
For compound 3 the middle estimate is 390-fold (2.59 log units) above the measured one; the measured number lies below the stated range.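

In this assay, the saturated chain carbon six bonds along the chain from an oxygen on an aromatic ring proves highly sensitive: (hydroxycarbamoyl)methyl in place of hydroxycarbamoyl gives a 460-fold lower number from compound 2 to compound 3 (2.67 log units; beyond the scatter). With that chain held constant, hydrogen in place of 1H-benzimidazol-2-yl on an aromatic carbon gives an at least 1500-fold lower number from compound 1 to compound 3 (3.19 log units; beyond the scatter), so this aromatic position is also sensitive, a point that compounds 1 and 2 alone could not show. Compound 1 gives a limit, not a number: the limit of > 20000 nM in this assay, at which 1 of the 3 values shown sits.

On these data alone, whether a longer chain keeps, improves or loses the value of compound 3 remains open. Also open, as far as these compounds go, is whether a carboxylic acid in place of the hydroxycarbamoyl end, or an amine in place of hydrogen on the aromatic carbon, retains any of this inhibition.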